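One Methyl Removed: From Compound 2 to Compound 3

A few compounds are considered here, and "the series" means these few. Any claim that something is new, unique, unknown or untested is made for them only; others in the source may bear on it.

Compound 1 `COc1cc(/C=C/c2ccc(NC(=O)/C=C/c3ccc(OC)c(OC)c3)cc2)cc(OC)c1` and compound 2 `COc1cc(/C=C/c2ccc(NC(=O)/C=C/c3cc(OC)c(OC)c(OC)c3)cc2)cc(OC)c1` share a core and differ by a single methoxy on an aromatic carbon. In a functional assay on HT-29 cells (Homo sapiens) for inhibition, read by MTT assay, with a stated time of 48 h (a higher number here means a weaker inhibitor, a lower number a stronger inhibitor), compound 1 gives 960 nM, and compound 2 gives 1820 nM. The step of a 1.9-fold higher number from compound 1 to compound 2 (0.28 log units; within the scatter) shows that the added methoxy left the number within the scatter, so the two compounds cannot be told apart on these data. Of the two numbers, compound 2 has the larger one, though the gap to compound 1 is within the scatter. Compound 3 `COc1cc(/C=C/c2ccc(NC(=O)/C=C/c3cc(OC)c(O)c(OC)c3)cc2)cc(OC)c1` arises from compound 2 by hydrogen in place of methyl on an oxygen on an aromatic ring. For the measured compounds named here, no measured step removes a methyl from such an oxygen; the only step in hand, from compound 1 to compound 2, concerns a different position and is small. The expected step, a 1.2-fold lower number from compound 2 to compound 3 (0.08 log units; within the scatter), is therefore nothing beyond the scatter. Compound 3 is estimated at 1500 nM in this assay, within 500 nM to 4500 nM.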

Compound 3, half-maximal inhibitory concentration: 3080 nM
Compound 3: middle estimate off by 2.1-fold (0.31 log units), on the low side, within the range that was stated.
By their numbers in this assay, from the lowest: compounds 1, 2 and 3 (each within the scatter of the next, the first and the last beyond it).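

In this assay the change from methoxy to hydroxy on this oxygen gives a 1.7-fold higher number from compound 2 to compound 3 (0.23 log units; within the scatter) and so, taken alone, cannot be told apart from no change at all. For the compounds shown here, the comparison with compound 1 reads differently: the 4-hydroxy-3,5-dimethoxyphenyl group gives a 3.2-fold higher number from compound 1 to compound 3 (0.51 log units; beyond the scatter) and is the first step here to pass the scatter, though only modestly, so two small steps in the same direction add up to a readable loss. Nothing available explains this loss.

The compounds shown leave open whether a longer chain on this oxygen, or an amine in place of the hydroxy, would move the number beyond the scatter from compound 2. They also leave open how a hydroxy would fare on the 3,4-dimethoxyphenyl group of compound 1.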